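Methyl on the azole: working notes on the series

The compounds below may be only part of what the source reports. "The series", "measured", "known", "first", "only" and "open" are said of these compounds alone.

Values in a functional assay on RKO cells (Homo sapiens) for cytotoxicity, read by resazurin assay, with a stated time of 72 h; a higher number here means a weaker inhibitor, a lower number a stronger inhibitor:
compound 1 `COc1ccc(Nc2nc(-n3c(C)nc4ccccc43)cs2)cc1`: 52500 nM
compound 2 `COc1ccc(Nc2nc(-n3cnc4ccccc43)cs2)cc1`: a limit of the assay, > 100000 nM
compound 3 `Cc1ccc(Nc2nc(-n3ccnc3C)cs2)cc1`: a limit of the assay, > 100000 nM

Compound 2 sits at the limit of > 100000 nM in this assay, at which 2 of the 3 values shown sit. From compound 2, the change methyl in place of hydrogen on an aromatic carbon gives an at least 1.9-fold lower number from compound 2 to compound 1 (0.27 log units; that floor lies within the scatter); the step is only a floor because compound 2 sits at the limit of > 100000 nM in this assay, at which 2 of the 3 values shown sit. How the core of compound 3 differs from that of compound 2 is not broken down here.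

Compound 4 `Cc1ccc(Nc2nc(-n3cc(C)nc3C)cs2)cc1` is not yet measured. It differs from compound 3 by methyl in place of hydrogen on an aromatic carbon. This is the same kind of change as from compound 2 to compound 1, not the same: there the methyl sat between two ring nitrogen atoms, next to the ring atom that bears a large group, in a fused system of two rings; here it sits next to the ring nitrogen, two ring bonds from the ring atom that bears a large group and two from the ring atom that bears a methyl group.

Compound 4 is expected near 80000 nM, between 35000 nM and 200000 nM. The expected step of an at least 1.2-fold lower number from compound 3 to compound 4 (0.09 log units; that floor lies within the scatter) rests on compound 3 giving only a limit, > 100000 nM, and on the earlier step of an at least 1.9-fold lower number from compound 2 to compound 1 (0.27 log units; that floor lies within the scatter).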

Compound 4, half-maximal inhibitory concentration: > 100000 nM
Compound 4: a limit, no number (the forecaster's own chance of this, stated with the estimate: 55%); middle value at least 1.2-fold (0.09 log units) away from the limit.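

Compound 3 and compound 4 both stand at a limit of the assay, so no step can be read between them: the limit of > 100000 nM in this assay, at which 3 of the 4 values shown sit.

On these data alone, whether methyl in place of hydrogen on this aromatic carbon changes the read-out at all remains open.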